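A few compounds are considered here, and "the series" means these few. Any claim that something is new, unique, unknown or untested is made for them only; others in the source may bear on it.

Measured so far in a functional assay on the whole organism (arterial blood) with Rattus norvegicus as the target (on this read-out lower numbers stand for an effect already at smaller amounts and higher numbers for an effect only at larger amounts of compound), and read as dose for half inhibition

- compound 1 `Cc1nc2cnccc2n1CC1CCN(C(=O)CNC(c2ccccc2)c2ccccc2)CC1` gives 0.067 mg/kg
- compound 2 `Cc1nc2cnccc2n1CC1CCN(C(=O)CC(C)(C)c2ccccc2)CC1` gives 0.012 mg/kg
- compound 3 `Cc1nc2cnccc2n1CC1CCN(C(=O)CC(O)(c2ccccc2)C(F)(F)F)CC1` gives 0.013 mg/kg

Compound 2 gives 0.012 mg/kg and sits with compound 3 at the low end of the three numbers, the two lying within the scatter of each other. Compound 1 gives 0.067 mg/kg, and against compound 2 its number is higher by a gap that lies beyond the scatter.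

Still to be measured is compound 4 `COc1ccccc1N(C)CC(=O)N1CCC(Cn2c(C)nc3cnccc32)CC1` which differs from compound 2 as follows (2-methoxyphenyl)(methyl)amino in place of 1-methyl-1-phenylethyl on a saturated chain carbon bound to a carbonyl carbon and carries (2-methoxyphenyl)(methyl)amino in place of 1-methyl-1-phenylethyl on a saturated chain carbon bound to a carbonyl carbon.

Among the measured compounds shown here, no two measured compounds differ in one place only, so no direct step guides the expectation. The closest reference is compound 1 (0.067 mg/kg) which also has an amino nitrogen on that saturated chain carbon. On this single comparison, a small move towards a higher number is expected, with the estimated step of a 2.5-fold higher number from compound 2 to compound 4 (0.40 log units; beyond the scatter) in this assay and considerable uncertainty around it. For compound 4 the estimated value is 0.03 mg/kg with an expected range of 0.008 mg/kg to 0.12 mg/kg before the measurement is known.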

Compound 4, dose for 50% inhibition: 0.063 mg/kg
For compound 4 the middle estimate is 2.1-fold (0.32 log units) below the measured one; measured number inside the range.
By their numbers in this assay, from the lowest: compounds 2 and 3 (each within the scatter of the next); then compounds 4 and 1 (each within the scatter of the next).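

Among the compounds shown here, exchanging 1-methyl-1-phenylethyl for (2-methoxyphenyl)(methyl)amino on a saturated chain carbon bound to a carbonyl carbon gives, in this assay, a 5.3-fold higher number from compound 2 to compound 4 (0.72 log units; beyond the scatter), the first step with one changed place, so the read-out does respond to what this position carries. Compound 1, which also has an amino nitrogen on that saturated chain carbon, gives 0.067 mg/kg, and compound 4 lies within the scatter of it, so among these four compounds the two with an amino nitrogen there stand apart from the low pair, compounds 2 and 3, with none going against this. No measurement at hand bears on what lies behind the step.

The exchange alters the atom on the chain and adds a methoxy group at once, so this single step cannot assign the change to either feature. Going by these compounds, a phenyl(methyl)amino group, without the methoxy, and a 1-(2-methoxyphenyl)-1-methylethyl group, without the amino nitrogen, would be the groups to separate the two, and what either would give remains open.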